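A few compounds are considered here, and "the series" means these few. Any claim that something is new, unique, unknown or untested is made for them only; others in the source may bear on it.

Compound 1 `COc1ccc(/C=C/C(=O)c2ccc(OC)c([N+](=O)[O-])c2)cc1` and compound 3 `COc1cccc(/C=C/C(=O)c2ccc(OC)c([N+](=O)[O-])c2)c1` are built from the same atoms joined differently; the difference between the two cores is not broken down here. In a functional assay on B16 cells (Mus musculus) for cytotoxicity, read by MTT assay, with a stated time of 3 days (a lower number here means a stronger inhibitor, a higher number a weaker inhibitor), compound 1 gives only a limit of the assay, > 100000 nM. Compound 3 likewise reaches only a limit of the assay in this assay, > 100000 nM. Compound 2 `COc1ccc(/C=C/C(=O)c2ccc(OC)c(N)c2)cc1` carries the change (amino in place of nitro on an aromatic carbon), and in this assay compound 2 gives 43000 nM, a step of an at least 2.3-fold lower number from compound 1 to compound 2 (0.36 log units; beyond the scatter) whose size is known only as a floor because of the limit of > 100000 nM in this assay, at which 2 of the 3 values shown sit. Compound 4 `COc1cccc(/C=C/C(=O)c2ccc(OC)c(N)c2)c1` makes the same change on the core of compound 3, (amino in place of nitro on an aromatic carbon). Since the earlier change gave an at least 2.3-fold lower number from compound 1 to compound 2 (0.36 log units; beyond the scatter), a step of similar size is expected, an at least 1.6-fold lower number from compound 3 to compound 4 (0.22 log units; that floor lies within the scatter). Compound 4 is therefore estimated at 60000 nM in this assay, between 25000 nM and 150000 nM.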

Compound 4, half-maximal inhibitory concentration: 33000 nM
The estimate for compound 4 lay 1.8-fold (0.26 log units) above the measured number, and the stated range covers the measured number.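

In this assay, amino in place of nitro on an aromatic carbon again goes with an at least 3.0-fold lower number from compound 3 to compound 4 (0.48 log units; beyond the scatter), so the lower number seen on the first core recurs on the second. Set side by side, the two steps read: the same change on two cores in this assay, an at least 2.3-fold lower number (0.36 log units; beyond the scatter) from compound 1 to compound 2 and an at least 3.0-fold lower number (0.48 log units; beyond the scatter) from compound 3 to compound 4; the limit leaves it open whether they differ Both steps therefore give only a shared direction and floors for their sizes, not a measure of how far the effect carries from one core to the other: the limit of > 100000 nM in this assay, at which 2 of the 4 values shown sit.

The compounds shown leave open how a hydroxyl group or an acetamide would compare with amino on that aromatic carbon. They also leave open whether the step would recur on a core with an ethoxy group in place of the methoxy group ortho to it.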